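The source may hold more compounds than are shown below. What is called first, only, known or untested is meant among the compounds shown, and "the series" means these compounds.

Series notes, cytotoxicity. Compound 1 `COc1ccc(/C=C/C(=O)/C(C)=C/c2ccccc2)cc1` and compound 2 `C/C(=C\c1ccccc1)C(=O)/C=C/c1ccc([N+](=O)[O-])cc1` share one core; compound 3 `COc1ccc(/C=C(\C)C(=O)/C=C/c2ccccc2)cc1` has the same atoms joined differently, and the difference between the two cores is not broken down here. In an ADME assay on J774.A1 cells (Mus musculus) for cytotoxicity, read by MTT assay, with a stated time of 48 h (a higher number here means that more compound is tolerated, a lower number that less compound is tolerated), compound 1 gives 51000 nM, and compound 2 gives 26000 nM. The change nitro in place of methoxy on an aromatic carbon thus moved the number a 2.0-fold lower number from compound 1 to compound 2 (0.29 log units; within the scatter). In this assay compound 3 gives 54000 nM. Compound 4 `C/C(=C\c1ccc([N+](=O)[O-])cc1)C(=O)/C=C/c1ccccc1` carries the same change on the core of compound 3, namely (nitro in place of methoxy on an aromatic carbon); the place lines of the two changes read alike word for word. From compound 3 to compound 4 a step of about a 2.0-fold lower number from compound 3 to compound 4 (0.30 log units; within the scatter) is expected in this assay, because compound 1 to compound 2 gave a 2.0-fold lower number from compound 1 to compound 2 (0.29 log units; within the scatter), a single precedent. On that basis compound 4 is estimated at 27000 nM, expected to fall between 14000 nM and 54000 nM.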

Compound 4, half-maximal cytotoxic concentration: 47300 nM
Beside the measured number, compound 4's estimate is 1.8-fold (0.24 log units) below it; low and high end bracket the measured number.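

In this assay nitro in place of methoxy on an aromatic carbon gives, on the core of compound 3, a 1.1-fold lower number from compound 3 to compound 4 (0.06 log units; within the scatter). Set beside the earlier step, the change carries from one core to the other with no difference that can be told apart: the same change on two cores in this assay, a 2.0-fold lower number (0.29 log units; within the scatter) from compound 1 to compound 2 and a 1.1-fold lower number (0.06 log units; within the scatter) from compound 3 to compound 4, 1.7-fold (0.24 log units) apart, within the scatter of two such steps. Neither step lies beyond the scatter, however, so this does not show that the change moves the number on either core, and two cores support no rule for a third.

Still open, on these data alone, is how an amine or a carboxylic acid at the same aromatic carbon would behave in this assay. Also open, as far as these compounds go, is whether any such group would give steps that agree between the two cores.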